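This account rests on a few compounds, and the source may have more. Where it says the series, first, only, none or still open, it means among the compounds named here.

Of the compounds shown here, three have so far been measured in an assay for inhibition of MAP kinase-interacting serine/threonine-protein kinase 1 (Homo sapiens), read by luminescence and ADP-Glo, with a stated time of 2 h (on this read-out lower numbers stand for stronger inhibition and higher numbers for weaker inhibition), and each of them returned only a limit of the assay rather than a number. Compound 1, with the structure `Cn1ncc2ccc(-c3ccc(=O)n(Cc4ccccc4)c3)cc21`, gives > 2000 nM, which is a limit and not a measured value. Compound 2, with the structure `O=C(N1CCOCC1)n1cc(-c2ccc3cn[nH]c3c2)ccc1=O`, gives > 2000 nM, again a limit. Compound 3, with the structure `O=c1ccc(-c2ccc3cc[nH]c3c2)cn1Cc1ccccc1`, gives > 2000 nM, a limit too. Compound 2 therefore sits at the limit of > 2000 nM in this assay, at which 3 of the 3 values shown sit, and nothing in these numbers sets it apart from compound 1 or compound 3.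

Compound 4, with the structure `Cn1cc(-c2ccc3cn[nH]c3c2)ccc1=O`, has not yet been measured. It differs from compound 2 in one place: methyl in place of (morpholin-4-yl)carbonyl on an aromatic nitrogen. Within the data shown here, no step between two measured compounds is available to show what such a change does in this assay, and the three values obtained so far are limits only, from which no direction can be read. The expectation is a step that the limit leaves unreadable from compound 2 to compound 4, that is, no step beyond the scatter in this assay. Compound 4 is accordingly estimated at 3000 nM, within a range from 800 nM to 20000 nM, with a real chance that the assay once more reports only a limit.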

Compound 4, half-maximal inhibitory concentration: > 2000 nM
Compound 4: only a limit was reported (the forecaster's own chance of this, stated with the estimate: 70%); the middle value lies beyond the limit too.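

In this assay no step can be read from compound 2 to compound 4, because both values are limits and not numbers: the limit of > 2000 nM in this assay, at which 4 of the 4 values shown sit.

The compounds shown leave open what methyl in place of (morpholin-4-yl)carbonyl does to inhibition, and which structure, if any, would give a measured number rather than a limit.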